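The compounds below may be only part of what the source reports. "The series", "measured", "known", "first", "only" and "open" are said of these compounds alone.

Compound 3, `CN1C=CN(C2NC(C(Cl)(Cl)Cl)=CN2c2ccc(S(N)(=O)=O)cc2)C=C1`, was tested in an ADME assay for inhibition of prostaglandin G/H synthase 1 (Rattus norvegicus), with a stated time of 30 min (a lower number here means a stronger inhibitor, a higher number a weaker inhibitor), where compound 3 gives 86000 nM. Two close relatives frame it. Compound 2, `CN1C=CN(C2SC(C(Cl)(Cl)Cl)=CN2c2ccc(S(N)(=O)=O)cc2)C=C1`, gives 88600 nM in this assay, and compound 1, `CN1C=CN(C2OC(C(F)(F)F)=CN2c2ccc(S(N)(=O)=O)cc2)C=C1`, gives 55600 nM. The number for compound 3 lies within the usual scatter of both: compound 2 sits nearest to it, and even compound 1, the furthest of the two, is not separated from it by more than the scatter. On these three numbers, therefore, compound 3 is neither set apart as stronger nor as weaker than its companions, and all three are weak inhibitors.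

The next compound, compound 4, `CC1=CN(c2ccc(S(N)(=O)=O)cc2)C(N2C=CN(C)C=C2)N1`, differs from compound 3 in one place: methyl in place of trichloromethyl on a double-bonded ring carbon of the shared core. Within the data shown here, no measured pair shows the effect of this change, so the step from compound 3 to compound 4 can only be expected, not read off. Since the three measured compounds all cluster in the same weak range, compound 4 is expected to stay near that range, with a step of a 1.2-fold lower number from compound 3 to compound 4 (0.09 log units; within the scatter) that is small and possibly not beyond the scatter. Compound 4 is accordingly estimated at 70000 nM, within a range from 25000 nM to 200000 nM.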

Compound 4, half-maximal inhibitory concentration in the prostaglandin G/H synthase 1 assay: 90700 nM
For compound 4 the middle estimate is 1.3-fold (0.11 log units) below the measured one; measured number inside the range.
By their numbers in the prostaglandin G/H synthase 1 assay, from the lowest: compounds 1, 3, 2 and 4 (each within the scatter of the next).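

Among these compounds, in the prostaglandin G/H synthase 1 assay, methyl in place of trichloromethyl on a double-bonded ring carbon gives a 1.1-fold higher number from compound 3 to compound 4 (0.02 log units; within the scatter), the first direct reading of any change at this position, and on this read-out the two groups cannot be told apart. Among the compounds shown here, compound 1, compound 2 and compound 3 offered no pair differing in one place, so they could show only that their numbers lay close together, not what a single exchange does. In a physicochemical assay for lipophilicity (on this read-out higher numbers stand for higher lipophilicity and lower numbers for lower lipophilicity), compound 3 gives 2.85 and compound 4 gives 1.44. The same exchange does separate the pair on lipophilicity, so for these two compounds a large difference in measured partition coefficient comes with no difference beyond the scatter in inhibition: the measured partition coefficient of compound 3, 2.85, and of compound 4, 1.44, a number 1.41 log units lower (beyond the scatter)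

The compounds shown compare only trichloromethyl and methyl at this position, so it remains open whether an amine, a carboxylic acid or a longer chain there would also leave the number in the same weak range. As far as these compounds go, it is equally open whether the exchange of trichloromethyl for methyl would read the same on the core of compound 2, or whether any group at this position can bring inhibition out of that weak range.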